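Adding Fluoro to a Pair That Reads Alike

The source may report more compounds than this note shows. Statements on the series, on what has been measured and on what is new or still open speak of the compounds shown alone.

Within the data shown here, in a functional assay, with a stated time of 10 min (a higher number here means a weaker inhibitor, a lower number a stronger inhibitor), compound 1 (`O=c1cc(/C=C/c2ccccc2)occ1O`) gives 2250 nM and lies within the scatter of the only other measured compound. That is compound 2 (`O=c1cc(/C=C/c2ccc(Cl)cc2)occ1O`) at 1950 nM in the same test. Compound 3 (`O=c1cc(/C=C/c2cccc(F)c2)occ1O`) has the core of compound 1 with fluoro in place of hydrogen on an aromatic carbon of its six-membered aromatic ring. Among the measured compounds shown here, the one measured step that bears on this, chloro in place of hydrogen (a 1.2-fold lower number from compound 1 to compound 2 (0.06 log units; within the scatter)), stays within the scatter, so no change beyond the scatter is expected here. The expected step (a 1.1-fold lower number from compound 1 to compound 3 (0.03 log units; within the scatter)) is therefore small. The estimated value for compound 3 is 2100 nM with 1000 nM to 4200 nM as its expected range.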

Compound 3, half-maximal inhibitory concentration: 3450 nM
Estimate against measurement, compound 3: 1.6-fold (0.22 log units) below; the measured number falls inside the stated range.
By their numbers in this assay, from the lowest: compounds 2, 1 and 3 (each within the scatter of the next).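

In this assay fluoro on an aromatic carbon, meta to a large group, gives a 1.5-fold higher number from compound 1 to compound 3 (0.19 log units; within the scatter) and so leaves compound 3 indistinguishable from compound 1. Among these compounds, the earlier pair held no group at this place, so this is the first reading for it, and swapping hydrogen for fluoro here has no effect that this test can resolve. No separate measurement accompanies this reading to help interpret it.

From the compounds shown here alone, whether a methoxy group, an amine or a carboxylic acid at this place would move the number beyond the scatter stays open.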